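From fluoro to methoxy: what to expect of compound 4

The compounds below may be only part of what the source reports. "The series", "measured", "known", "first", "only" and "open" are said of these compounds alone.

In a functional assay on L1210 cells (Mus musculus) for inhibition (on this read-out lower numbers stand for stronger inhibition and higher numbers for weaker inhibition), compound 1 `O=C1/C(=C/c2cccc(Cl)c2)Cc2ccccc21` reads 41200 nM and compound 2 `COc1cccc(/C=C2\Cc3ccccc3C2=O)c1` reads 217000 nM on a shared core. Compound 3 `O=C1CCCCC/C1=C\c1cccc(F)c1` carries a different core and reads 382000 nM in the same test. That number lies within the usual scatter of the value for compound 2 and is clearly higher than the value for compound 1.

Compound 4 `COc1cccc(/C=C2\CCCCCC2=O)c1` keeps the core of compound 3 and changes one group (methoxy in place of fluoro on an aromatic carbon), so that methoxy stands in place of fluoro on an aromatic carbon.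

Among the compounds with values here, only one measured step bears on this change. Methoxy in place of chloro on an aromatic carbon gave a 5.3-fold higher number from compound 1 to compound 2 (0.72 log units; beyond the scatter) in this assay as a modest move beyond the scatter. That step leaves chloro rather than fluoro and sits on another core, which makes it a rough guide only. Compound 3 already stands level with compound 2 at 217000 nM and a smaller move in the same direction is therefore expected. The step expected here (a 1.7-fold higher number from compound 3 to compound 4 (0.23 log units; within the scatter)) would lie within the scatter. Compound 4 is estimated at 650000 nM (expected range 280000 nM to 1500000 nM).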

Compound 4, half-maximal inhibitory concentration: 283000 nM
Beside the measured number, compound 4's estimate is 2.3-fold (0.36 log units) above it; low and high end bracket the measured number.
By their numbers in this assay, from the lowest: compound 1; then compounds 2, 4 and 3 (each within the scatter of the next).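

On the core of compound 3, methoxy in place of fluoro on an aromatic carbon gives a 1.3-fold lower number from compound 3 to compound 4 (0.13 log units; within the scatter) in this assay, so this swap at this position leaves no change that the test can tell apart from ordinary variation. Within the data shown here, the only earlier step to bring in methoxy, a 5.3-fold higher number from compound 1 to compound 2 (0.72 log units; beyond the scatter) in this assay, did go beyond the scatter, so methoxy entering the ring does not move the number by the same amount in every setting. These two steps differ both in the group that leaves, chloro or fluoro, and in the core, and no measurement shown explains why they differ or which of those two differences matters.

Still open, on these data alone, is how chloro would read on the core of compound 3, which would show whether the lower number of compound 1 comes with the chloro group or with its core. Also open, as far as these compounds go, is whether a quite different group at this same place on the ring, such as an amine or a carboxylic acid, would shift the number beyond the scatter.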